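Ring size and amide swap on the aminocyclohexanol arm

The source may hold more compounds than are shown below. What is called first, only, known or untested is meant among the compounds shown, and "the series" means these compounds.

Compound 1 `N#Cc1cnc(NCc2cnccc2C(F)(F)F)cc1NC[C@H]1C[C@H](O)C1`: 700 nM
Compound 2 `N#Cc1cnc(NCc2cnccc2C(F)(F)F)cc1N[C@H]1CC[C@H](O)CC1`: 350 nM
Compound 3 `CC1(C)C[C@H](Nc2cc(NCc3cnccc3C(F)(F)F)ncc2C#N)CC[C@H]1O`: 100 nM

In an assay on isolated protein for inhibition of protein kinase C theta type (Homo sapiens), read by TR-FRET, with a stated time of 2 h (on this read-out higher numbers stand for weaker inhibition and lower numbers for stronger inhibition), compound 3 gives the lowest of the three numbers: a 3.5-fold lower number from compound 2 to compound 3 (0.54 log units; beyond the scatter) and a 7.0-fold lower number from compound 1 to compound 3 (0.85 log units; beyond the scatter), whereas a 2.0-fold lower number from compound 1 to compound 2 (0.30 log units; within the scatter). Compound 4 `CC1(C)[C@@H](Nc2cc(NCc3cnccc3C(F)(F)F)ncc2C#N)C[C@H]1C(N)=O` differs from compound 3 by 3-carbamoyl-2,2-dimethylcyclobutyl in place of 4-hydroxy-3,3-dimethylcyclohexyl on a nitrogen on an aromatic ring. Among the measured compounds shown here, no measured step covers a change from a six-membered to a four-membered ring on this nitrogen, nor a hydroxyl to a carbamoyl; the gains seen on the way to compound 3 followed the 4-hydroxy-3,3-dimethylcyclohexyl group itself, which leaves. Compound 4 is therefore expected to give a somewhat higher number in this assay, about 250 nM (range 60 nM to 1000 nM), an estimated step of a 2.5-fold higher number from compound 3 to compound 4 (0.40 log units; beyond the scatter).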

Compound 4, half-maximal inhibitory concentration: 140 nM
Estimate against measurement, compound 4: 1.8-fold (0.25 log units) above; the measured number falls inside the stated range.
By their numbers in this assay, from the lowest: compounds 3 and 4 (each within the scatter of the next); then compounds 2 and 1 (each within the scatter of the next).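

In this assay, the four-membered 3-carbamoyl-2,2-dimethylcyclobutyl group on this nitrogen stands level with the six-membered 4-hydroxy-3,3-dimethylcyclohexyl group, with a 1.4-fold higher number from compound 3 to compound 4 (0.15 log units; within the scatter), so this position accepts either ring size and either a carbamoyl or a hydroxyl. The group also improves on the two unmethylated arms, with a 2.5-fold lower number from compound 2 to compound 4 (0.40 log units; beyond the scatter) and a 5.0-fold lower number from compound 1 to compound 4 (0.70 log units; beyond the scatter). Nothing available here explains these steps.

Going by these compounds, whether a carboxylic acid or an aminomethyl group in place of the carbamoyl would hold this level stays open, as does the contribution of the two methyl groups on the four-membered ring.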